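Furan-2-yl for Thiophen-2-yl on the Shared Nucleoside Core

The compounds below may be only part of what the source reports. "The series", "measured", "known", "first", "only" and "open" are said of these compounds alone.

The measured compounds in a functional assay on A549 cells (Homo sapiens), read by MTT assay, with a stated time of 72 h; on this read-out higher numbers stand for weaker inhibition and lower numbers for stronger inhibition:
compound 1, `Nc1nc(N)c2c(-c3cc4ccccc4o3)cn([C@@H]3O[C@H](CO)[C@@H](O)[C@H]3O)c2n1`, gives > 20000 nM, which is a limit of the assay.
compound 2, `O=c1[nH]cnc2c1c(-c1ccsc1)cn2[C@@H]1O[C@H](CO)[C@@H](O)[C@H]1O`, gives > 20000 nM, which is a limit of the assay.
compound 3, `O=c1[nH]cnc2c1c(-c1cccs1)cn2[C@@H]1O[C@H](CO)[C@@H](O)[C@H]1O`, gives > 20000 nM, which is a limit of the assay.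

Compound 3 therefore stands at the limit of this assay, not at a number. Within the data shown here, the one step between measured compounds, a step that the two limits leave unreadable from compound 2 to compound 3, cannot be read in size because both of its ends are limits. Compound 4, `O=c1[nH]cnc2c1c(-c1ccco1)cn2[C@@H]1O[C@H](CO)[C@@H](O)[C@H]1O`, differs from compound 3 in one place: furan-2-yl in place of thiophen-2-yl on an aromatic carbon. Among the measured compounds shown here, no measured step covers this exchange of heteroatom in the five-membered ring; the unreadable step from compound 2 to compound 3 is the nearest comparison and gives no size. Because of the limit of > 20000 nM in this assay, at which 3 of the 3 values shown sit, compound 4 is expected to remain at the limit as well, and the expected step that the limit leaves unreadable from compound 3 to compound 4 is therefore none beyond the scatter. Compound 4 is estimated at 30000 nM, with a range from 8000 nM to 100000 nM, most likely reported only as a limit.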

Compound 4, half-maximal inhibitory concentration: > 20000 nM
Compound 4: a limit, no number; the forecaster's own chance of this, stated with the estimate: 85%; the middle value does not contradict the limit.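

Compound 4 gives > 20000 nM, which is a limit of the assay and not a number. Among these compounds, no step among compound 2, compound 3 and compound 4 can be read in size: the limit of > 20000 nM in this assay, at which 4 of the 4 values shown sit. The compounds shown leave open how furan-2-yl, thiophen-2-yl and thiophen-3-yl rank on the shared core in this assay.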